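Hemolysis of a bis-furan amidine after swapping chloro for methoxy

The source may hold more compounds than are shown below. What is called first, only, known or untested is meant among the compounds shown, and "the series" means these compounds.

Measured compounds:
- compound 1 `N=C(N)c1ccc(-c2ccc(-c3cncc4ccccc34)s2)s1`: "non-toxic" (no number reported)
- compound 2 `N=C(N)c1ccc(-c2ccc(-c3ccc(F)cc3)o2)o1`: "non-toxic" (no number reported)
- compound 3 `N=C(N)c1ccc(-c2ccc(-c3ccc(Cl)cc3)o2)o1`: 14%

All three compounds were tested in an ADME assay on cells (Erythrocyte, Homo sapiens) for activation, read by hemolysis, with a stated time of 30 min, tested at 1.25 mM; on this read-out lower numbers stand for a weaker effect and higher numbers for a stronger effect at the one concentration tested. For compound 1 the result is reported only in words, as "non-toxic" (no number reported), with no number attached. For compound 2 the result is likewise reported only in words, as "non-toxic" (no number reported), with no number attached. For the measured compounds named here, compound 3 is the only one with a number: in this assay compound 3 gives 14%, a modest degree of red-cell breakage.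

The next compound, compound 4 `COc1ccc(-c2ccc(-c3ccc(C(=N)N)o3)o2)cc1`, keeps the whole core of compound 3 and differs in one spot: methoxy in place of chloro on an aromatic carbon. Going by the values given here, no measured pair with this exact change exists, so the expected size of the step cannot be read off earlier data.

Given that compound 3 already sits low and the other two compounds are described as non-toxic, the step from compound 3 to compound 4 is expected to stay small, most likely within the usual scatter, a number 4 percentage points lower from compound 3 to compound 4 (within the scatter). Compound 4 is therefore estimated at 10%, in a range from 2% to 25%.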

Compound 4, a percentage reported as activity, at one concentration (the size of the read-out at that concentration, not a potency): "non-toxic" (no number reported)
Compound 4: no number reported, so the estimate cannot be set against anything.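

For the compounds shown here, compound 4 is reported in words only, so no step from compound 3 to compound 4 can be read in this assay. No available evidence bears on this result. The compounds shown leave open how large, as a number, the hemolysis with methoxy is compared with chloro.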